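Nitro to trifluoromethyl on the aryl group: an estimate

A few compounds are considered here, and "the series" means these few. Any claim that something is new, unique, unknown or untested is made for them only; others in the source may bear on it.

Measured so far:
- Compound 1 `COc1cc(C(=O)c2sc(-c3ccc(-c4ccccc4)cc3)cc2N)cc(OC)c1OC`; in a functional assay on CCRF-CEM cells (Homo sapiens) for antiproliferative activity (a higher number here means a weaker inhibitor, a lower number a stronger inhibitor), compound 1 gives > 10000 nM, which is a limit of the assay and not a number.
- Compound 2 `COc1cc(C(=O)c2sc(-c3ccc([N+](=O)[O-])cc3)cc2N)cc(OC)c1OC`; in this assay compound 2 gives 99 nM.
- Compound 3 `COc1cc(C(=O)c2sc(-c3ccsc3)cc2N)cc(OC)c1OC`; in this assay compound 3 gives 9.6 nM.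

Among the numbers shown, compound 2 stands highest, with compound 3 the nearest, while compound 1 sits at the limit of > 10000 nM in this assay, at which 1 of the 3 values shown sits. Compound 4 `COc1cc(C(=O)c2sc(-c3ccc(C(F)(F)F)cc3)cc2N)cc(OC)c1OC` differs from compound 2 by trifluoromethyl in place of nitro on an aromatic carbon. Among the measured compounds shown here, two measured steps touch the same group: an at least 100-fold lower number from compound 1 to compound 2 (2.00 log units; beyond the scatter) and a 10-fold lower number from compound 2 to compound 3 (1.01 log units; beyond the scatter), both large. Neither involves trifluoromethyl, so they only show that what sits on this aryl group can move the number a great deal. In this assay a modest shift is expected, a 2.0-fold higher number from compound 2 to compound 4 (0.31 log units; beyond the scatter). Compound 4 is therefore estimated at 200 nM, within 40 nM to 1500 nM.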

Compound 4, half-maximal inhibitory concentration: 270 nM
Estimate against measurement, compound 4: 1.4-fold (0.13 log units) below; measured number inside the range.
By their numbers in this assay, from the lowest: compound 3; then compound 2; then compound 4. At a limit, above all of these: compound 1.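

Replacing nitro with trifluoromethyl on the phenyl ring gives a 2.7-fold higher number from compound 2 to compound 4 (0.44 log units; beyond the scatter), so these two small groups leave the number in a similar range, unlike the larger swaps seen so far. Moving from thiophen-3-yl to 4-(trifluoromethyl)phenyl gives a 28-fold higher number from compound 3 to compound 4 (1.45 log units; beyond the scatter), so this phenyl compound also stays well short of the thiophene. Trifluoromethyl in place of the outer phenyl gives an at least 37-fold lower number from compound 1 to compound 4 (1.56 log units; beyond the scatter), and that size is only a bound, the value of compound 1 being a limit: the limit of > 10000 nM in this assay, at which 1 of the 4 values shown sits.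

From the compounds shown here alone, how an amine, a methoxy group or a bare hydrogen would score at this place on the phenyl ring remains open.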